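From a bromophenyl to a hydroxyphenyl on the shared core

The source may hold more compounds than are shown below. What is called first, only, known or untested is meant among the compounds shown, and "the series" means these compounds.

Of the compounds shown here, three sharing one core have been tested in a functional assay on U2OS cells (Homo sapiens) for cytotoxicity, read by MTT assay, with a stated time of 48 h; a lower number here means a stronger inhibitor, a higher number a weaker inhibitor. Compound 1 `Fc1cccc(-c2nc(Nc3ccccc3)c3cc(F)ccc3n2)c1` gives 47600 nM. Compound 2 `COc1ccccc1Nc1nc(-c2cccc(F)c2)nc2ccc(F)cc12` reaches only the limit of this assay, > 50000 nM. Compound 3 `Fc1cccc(-c2nc(Nc3cccc(Br)c3)c3cc(F)ccc3n2)c1` likewise reaches only the limit, > 50000 nM. Because of the limit of > 50000 nM in this assay, at which 2 of the 3 values shown sit, neither the step of an at least 1.0-fold higher number from compound 1 to compound 2 (0.02 log units; that floor lies within the scatter) nor the step of an at least 1.0-fold higher number from compound 1 to compound 3 (0.02 log units; that floor lies within the scatter) can be given a size, and the step that the two limits leave unreadable from compound 2 to compound 3 cannot be read either. Compound 3 therefore stands at the weak end of what this assay can report, not separable from compound 2.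

Compound 4 `Oc1ccccc1Nc1nc(-c2cccc(F)c2)nc2ccc(F)cc12` differs from compound 3 by 2-hydroxyphenyl in place of 3-bromophenyl on a nitrogen on an aromatic ring. Among the measured compounds shown here, the only measured steps that touch this position are the two from compound 1, both of which ended at the limit, so no direction beyond the scatter is expected. The step that the limit leaves unreadable from compound 3 to compound 4 is therefore expected to stay within the scatter. Compound 4 is estimated at 60000 nM, with a range from 25000 nM to 200000 nM, most likely again only a limit.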

Compound 4, half-maximal inhibitory concentration: 41400 nM
Beside the measured number, compound 4's estimate is 1.4-fold (0.16 log units) above it, within the range that was stated.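

With a hydroxy group added to the phenyl ring, the shared core gains a second real number in this assay, and the step is a 1.1-fold lower number from compound 1 to compound 4 (0.06 log units; within the scatter). Hydrogen in place of methyl on the oxygen gives an at least 1.2-fold lower number from compound 2 to compound 4 (0.08 log units; that floor lies within the scatter), and 2-hydroxyphenyl in place of 3-bromophenyl on the nitrogen gives an at least 1.2-fold lower number from compound 3 to compound 4 (0.08 log units; that floor lies within the scatter), so neither change is shown to move the number beyond the scatter. These last two steps have only a floor and no true size: the limit of > 50000 nM in this assay, at which 2 of the 4 values shown sit.

Going by these compounds, it remains open whether an amine or a carboxylic acid on this phenyl ring would move the number beyond the scatter. A longer chain on the oxygen is also an open case, as is the true distance of compound 2 and compound 3 from compound 4.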